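Replacing the Nitrophenyl Amide Group in Compound 1

The source may report more compounds than this note shows. Statements on the series, on what has been measured and on what is new or still open speak of the compounds shown alone.

Compound 1 `O=C1c2ccccc2C(=O)N1CCOC(=S)N(C(=O)c1cccc([N+](=O)[O-])c1)c1ccc(Cl)cc1` was tested in an ADME assay on MT4 cells (Homo sapiens) for cytotoxicity, read by MTT assay (a lower number here means that less compound is tolerated, a higher number that more compound is tolerated), and gave 18000 nM. Among the numbers measured this is the lower of the two; its nearest neighbour is compound 3 `Cc1ccc(N(C(=O)c2cccc([N+](=O)[O-])c2)C(=S)OCCN2C(=O)c3ccccc3C2=O)cc1`, which gives 100000 nM, so that the change of methyl in place of chloro on an aromatic carbon is read as a 5.6-fold higher number from compound 1 to compound 3 (0.74 log units; beyond the scatter). Compound 2 `Cc1ccc(N(C(=O)c2ccccc2C)C(=S)OCCN2C(=O)c3ccccc3C2=O)cc1` reached only a limit of the assay, > 100000 nM. Because of the limit of > 100000 nM in this assay, at which 1 of the 3 values shown sits, the step of 3-nitrophenyl in place of 2-methylphenyl on a carbonyl carbon is a number no higher from compound 2 to compound 3 (the limit leaves the size open).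

Compound 4 `O=C1c2ccccc2C(=O)N1CCOC(=S)N(C(=O)c1cc(F)cc(F)c1)c1ccc(Cl)cc1` differs from compound 1 by 3,5-difluorophenyl in place of 3-nitrophenyl on a carbonyl carbon. Among the measured compounds shown here, the only measured step at the same carbonyl carbon is the one from compound 2 to compound 3, whose size stays open, while the step from compound 1 to compound 3 alters a different position. For the measured compounds named here, no step of readable size therefore bears on this change, and nothing beyond the scatter can be predicted with confidence in this assay, so the expectation is a number near that of compound 1 with a wide spread. Compound 4 is expected to give about 25000 nM, estimated to lie between 6000 nM and 100000 nM. This estimate means an expected step of a 1.4-fold higher number from compound 1 to compound 4 (0.14 log units; within the scatter).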

Compound 4, half-maximal cytotoxic concentration: 59000 nM
Estimate against measurement, compound 4: 2.4-fold (0.37 log units) below; the range from low to high includes it.
By their numbers in this assay, from the lowest: compound 1; then compounds 4 and 3 (each within the scatter of the next).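

Among the compounds shown here, at the carbonyl carbon whose other neighbour is the amide-type nitrogen, 3,5-difluorophenyl in place of 3-nitrophenyl gives the first step of readable size at this place in this assay, a 3.3-fold higher number from compound 1 to compound 4 (0.52 log units; beyond the scatter). For the compounds shown here, the only earlier step at this carbonyl carbon, between 2-methylphenyl and 3-nitrophenyl, cannot be read, because its size depends on a value that is a limit of the assay: the limit of > 100000 nM in this assay, at which 1 of the 4 values shown sits. The new step therefore shows that, with the chloro group held in place, the group on this carbonyl carbon changes how much compound is tolerated, although nothing measured here explains why.

The compounds shown leave open whether the same exchange would give a step of similar size with methyl in place of chloro on the aromatic carbon. They also leave open how a single fluorine, a pyridine ring, a carboxylic acid or a longer alkyl chain on this carbonyl carbon would read in this assay.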